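Enones with a shared core: sulfide and sulfone pairs

This account rests on a few compounds, and the source may have more. Where it says the series, first, only, none or still open, it means among the compounds named here.

Compound 1 `O=C(/C(=C\c1ccc(O)c([N+](=O)[O-])c1)SCc1ccc(Br)cc1)c1ccc(Br)cc1` carries a sulfide; in a functional assay on DU-145 cells (Homo sapiens) for inhibition, read by trypan blue exclusion, with a stated time of 96 h (a higher number here means a weaker inhibitor of growth, a lower number a stronger inhibitor of growth), compound 1 gives 10000 nM. Compound 3 `O=C(/C(=C\c1cc(Cl)c(O)c(Cl)c1)SCc1ccc(Br)cc1)c1ccc(Br)cc1` differs by 3,5-dichloro-4-hydroxyphenyl in place of 4-hydroxy-3-nitrophenyl on a double-bonded chain carbon bound to a double-bonded chain carbon and gives 10000 nM; the step of no change at the digits printed from compound 1 to compound 3 (within the scatter). Compound 2 `O=C(/C(=C\c1ccc(O)c([N+](=O)[O-])c1)S(=O)(=O)Cc1ccc(Br)cc1)c1ccc(Br)cc1` carries the sulfone and gives 10000 nM; the difference between the cores of compound 1 and compound 2 is not broken down here, and the values of compound 2 and compound 1 sit at the same digits. Compound 4 `O=C(/C(=C\c1cc(Cl)c(O)c(Cl)c1)S(=O)(=O)Cc1ccc(Br)cc1)c1ccc(Br)cc1` is not yet measured. It differs from compound 2 by 3,5-dichloro-4-hydroxyphenyl in place of 4-hydroxy-3-nitrophenyl on a double-bonded chain carbon bound to a double-bonded chain carbon, the same change as from compound 1 to compound 3. Because no change at the digits printed from compound 1 to compound 3 (within the scatter) left the value unchanged, the step of no change at the digits printed from compound 2 to compound 4 (within the scatter) is expected to be flat as well. Compound 4 is estimated at 10000 nM, in a range from 5000 nM to 20000 nM.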

Compound 4, concentration for 50% growth inhibition: 25000 nM
Beside the measured number, compound 4's estimate is 2.5-fold (0.40 log units) below it; the whole stated range lies below it.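

In this assay, 3,5-dichloro-4-hydroxyphenyl in place of 4-hydroxy-3-nitrophenyl on the sulfone core gives a 2.5-fold higher number from compound 2 to compound 4 (0.40 log units; beyond the scatter). Set beside the same change on the sulfide core, this step cannot be told apart from the earlier one: the same change on two cores in this assay, no change at the digits printed (within the scatter) from compound 1 to compound 3 and a 2.5-fold higher number (0.40 log units; beyond the scatter) from compound 2 to compound 4, 2.5-fold (0.40 log units) apart, within the scatter of two such steps. The change therefore carries across these two cores without a difference beyond the scatter, but one pair per core does not show that it would behave alike on other cores.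

Still open, going by these compounds, is how the series would respond to an amine or a carboxylic acid on that aromatic ring. Also open, on these data alone, is where a sulfoxide would fall relative to the sulfide and the sulfone.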